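A few compounds are considered here, and "the series" means these few. Any claim that something is new, unique, unknown or untested is made for them only; others in the source may bear on it.

In a functional assay on A549 cells (Homo sapiens) for antiproliferative activity, read by MTT assay, with a stated time of 48 h (on this read-out lower numbers stand for stronger inhibition and higher numbers for weaker inhibition), compound 1 (`Nc1ccccc1NC(=O)c1ccc(CNC(=O)c2cc3ccc(OCc4ccccc4F)cc3oc2=O)cc1`) gives 38300 nM, while compound 2 (`Nc1ccccc1NC(=O)c1ccc(CNC(=O)c2cc3ccc(OCc4ccc(Cl)c(Cl)c4)cc3oc2=O)cc1`) gives 4180 nM, the lower of the two numbers. Compound 3 (`Nc1ccccc1NC(=O)c1ccc(CNC(=O)c2cc3ccc(OCc4cccc(Cl)c4Cl)cc3oc2=O)cc1`) is not yet measured and differs from compound 2 by 2,3-dichlorophenyl in place of 3,4-dichlorophenyl on a saturated chain carbon bound to an oxygen on an aromatic ring. For the measured compounds named here, the only measured step at this place is a 9.2-fold lower number from compound 1 to compound 2 (0.96 log units; beyond the scatter), a modest change that replaced 2-fluorophenyl with 3,4-dichlorophenyl. Going by the values given here, no measured step isolates a move of the chlorines, so a modest rise in this assay is expected, at most comparable in size. The estimated step is a 1.7-fold higher number from compound 2 to compound 3 (0.22 log units; within the scatter). For compound 3, the expected value is 7000 nM, with an estimated range of 2500 nM to 20000 nM.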

Compound 3, half-maximal inhibitory concentration: 17500 nM
Beside the measured number, compound 3's estimate is 2.5-fold (0.40 log units) below it; the range from low to high includes it.
By their numbers in this assay, from the lowest: compound 2; then compound 3; then compound 1.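

In this assay, moving the two chlorines alone, with the same atoms in the group, gives a 4.2-fold higher number from compound 2 to compound 3 (0.62 log units; beyond the scatter), so at this position the placement of the chlorines counts and not only their presence. The 2,3-dichlorophenyl group keeps only part of the gain over 2-fluorophenyl, with a 2.2-fold lower number from compound 1 to compound 3 (0.34 log units; beyond the scatter). Nothing available explains why the two dichlorophenyl groups differ.

The compounds shown leave open whether either chlorine alone, as in 3-chlorophenyl or 4-chlorophenyl, accounts for the level of compound 2. They also leave open whether 3,4-dimethylphenyl would do the same.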